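Swapping the para group on the sulfonyl aryl ring

This account rests on a few compounds, and the source may have more. Where it says the series, first, only, none or still open, it means among the compounds named here.

Measured so far:
Compound 1 `CCN(CC)c1ccc2cc(C(=O)c3ccc(N4CCN(C(=O)CN5CCN(S(=O)(=O)C6CC6)CC5)CC4)cc3)oc2c1`: 15300 nM
Compound 2 `CCN(CC)c1ccc2cc(C(=O)c3ccc(N4CCN(C(=O)CN5CCN(S(=O)(=O)c6ccc(OC(F)(F)F)cc6)CC5)CC4)cc3)oc2c1`: 24400 nM

Of the compounds shown here, two sharing one core have been tested in a functional assay on SGC-7901 cells (Homo sapiens) for cytotoxicity, read by MTT assay, with a stated time of 48 h; a higher number here means a weaker inhibitor, a lower number a stronger inhibitor. Among the compounds with values here, compound 2 gives 24400 nM there, and compound 1 gives 15300 nM; the only measured step, a 1.6-fold higher number from compound 1 to compound 2 (0.20 log units; within the scatter), is a change on the sulfonyl sulfur and lies within the scatter, so neither compound can be called stronger than the other.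

Compound 3 `CCN(CC)c1ccc2cc(C(=O)c3ccc(N4CCN(C(=O)CN5CCN(S(=O)(=O)c6ccc(C#N)cc6)CC5)CC4)cc3)oc2c1` is the next compound. It differs from compound 2 in one place: cyano in place of trifluoromethoxy on an aromatic carbon. Within the data shown here, no measured step touches this position, so nothing directly bears on the change. Among the measured compounds shown here, the one step that exists, a 1.6-fold higher number from compound 1 to compound 2 (0.20 log units; within the scatter), shows that a large change at the sulfonyl end moved the number little. By analogy the step of a 1.2-fold lower number from compound 2 to compound 3 (0.09 log units; within the scatter) is expected to stay within the scatter, in no clear direction. Compound 3 is therefore estimated at 20000 nM, within a range from 8000 nM to 50000 nM.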

Compound 3, half-maximal inhibitory concentration: > 40000 nM
Compound 3: a limit, no number (the forecaster's own chance of this, stated with the estimate: 10%); middle value at least 2.0-fold (0.30 log units) away from the limit.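

Compound 3 gives no number, only a limit of the assay: the limit of > 40000 nM in this assay, at which 1 of the 3 values shown sits. Trading the trifluoromethoxy group for cyano on the same ring carbon gives an at least 1.6-fold higher number from compound 2 to compound 3 (0.21 log units; that floor lies within the scatter), and since that floor lies within the scatter, this swap alone cannot be ranked. The comparison with the cyclopropyl group goes further, with an at least 2.6-fold higher number from compound 1 to compound 3 (0.41 log units; beyond the scatter) in this assay, so the group on the sulfonyl sulfur can matter here, which the step between compound 1 and compound 2 did not show.

Going by these compounds, both new steps are floors, so their true size stays open. Also open, on these data alone, is what an amine, a methoxy group or a plain hydrogen on this ring carbon would do to the number in this assay.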